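Replacing 3,4,5-trimethoxyphenyl in a cytotoxic series

This account rests on a few compounds, and the source may have more. Where it says the series, first, only, none or still open, it means among the compounds named here.

In a functional assay on A549 cells (Homo sapiens) for cytotoxicity, read by MTT assay, with a stated time of 48 h (a higher number here means a weaker inhibitor, a lower number a stronger inhibitor), compound 1 `COc1cc(C2=NOC(COc3ccc(-c4nnnn4-c4cc(OC)c(OC)c(OC)c4)cc3N)C2)cc(OC)c1OC` gives 2060 nM and compound 2 `COc1ccc(-c2nnnn2-c2cc(OC)c(OC)c(OC)c2)cc1N` gives 2630 nM in the same test. Going by the values given here, these two numbers lie within the usual scatter of each other, so compound 1 stands level with the only other measured compound, and neither can be ranked ahead.

Compound 3 `COc1ccc(F)c(C2=NOC(COc3ccc(-c4nnnn4-c4cc(OC)c(OC)c(OC)c4)cc3N)C2)c1` has not yet been measured and departs from compound 1 at one place. With 2-fluoro-5-methoxyphenyl in place of 3,4,5-trimethoxyphenyl on a carbon with a double bond to nitrogen as the counted difference, the change is 2-fluoro-5-methoxyphenyl in place of 3,4,5-trimethoxyphenyl on a carbon with a double bond to nitrogen. Among the compounds with values here, no measured pair shows what a change at this place does. The expectation therefore starts from compound 1 at 2060 nM as the closest reference, and it carries wide uncertainty in both directions. In this assay the expected move, a 1.1-fold lower number from compound 1 to compound 3 (0.06 log units; within the scatter) as estimated, stays within the scatter, with no direction favoured. The estimate for compound 3 is 1800 nM with an expected range from 500 nM to 6500 nM once it is measured.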

Compound 3, half-maximal inhibitory concentration: 1510 nM
Compound 3: middle estimate off by 1.2-fold (0.08 log units), on the high side; low and high end bracket the measured number.
By their numbers in this assay, from the lowest: compounds 3, 1 and 2 (each within the scatter of the next).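

Going by these compounds alone, this is the first measured step at this position: in this assay, placing 2-fluoro-5-methoxyphenyl on the carbon with a double bond to nitrogen in place of 3,4,5-trimethoxyphenyl gives a 1.4-fold lower number from compound 1 to compound 3 (0.13 log units; within the scatter) and leaves the two compounds level. For this one pair, the full 3,4,5-trimethoxyphenyl group at this place is therefore not required to keep the number within the scatter, even though the entering group has fewer heavy atoms and hydrogen-bond acceptors, and brings a fluorine in place of two of the oxygens. No evidence is available that explains this result.

The compounds shown do not separate the contribution of the fluorine from that of the methoxy group, since the whole aryl group differs between compound 1 and compound 3. Going by these compounds, it also remains open whether a plain phenyl, or a phenyl carrying an amine or a carboxylic acid, on this same carbon would give a number beyond the scatter of compound 1, so the limits of what this position accepts are still unknown.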